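Replacing 3-methylphenyl with 4-fluorophenyl on an amine nitrogen

A few compounds are considered here, and "the series" means these few. Any claim that something is new, unique, unknown or untested is made for them only; others in the source may bear on it.

In a functional assay on A549 cells (Homo sapiens) for antiproliferative activity, read by MTT assay, with a stated time of 24 h (a lower number here means a stronger inhibitor, a higher number a weaker inhibitor), compound 1 (`O=C(NNc1ccccc1Cl)c1ccc(NS(=O)(=O)c2cnc(O)nc2O)cc1`) gives 3340 nM as its half-maximal inhibitory concentration. In this assay compound 2 (`Cc1cccc(NNC(=O)c2cccc(NS(=O)(=O)c3cnc(O)nc3O)c2)c1`) stands at > 20000 nM as a limit, not a number. Compound 3 (`O=C(NNc1ccc(F)cc1)c1cccc(NS(=O)(=O)c2cnc(O)nc2O)c1`), not yet measured, carries 4-fluorophenyl in place of 3-methylphenyl on an amine nitrogen. Among the compounds with values here, no measured pair of compounds shows what this change does, so the expected step of an at least 1.3-fold lower number from compound 2 to compound 3 (0.12 log units; that floor lies within the scatter) is none beyond the scatter, in either direction. In this assay compound 3 is expected at 15000 nM with a range from 5000 nM to 40000 nM as its estimate.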

Compound 3, half-maximal inhibitory concentration: > 20000 nM
Compound 3 gave a limit, no number (the forecaster's own chance of this, stated with the estimate: 50%); middle value at least 1.3-fold (0.12 log units) away from the limit.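

Compound 2 and compound 3 both sit at a limit in this assay, not at a number, so no step between them can be read: the limit of > 20000 nM in this assay, at which 2 of the 3 values shown sit.

From the compounds shown here alone, whether 4-fluorophenyl in place of 3-methylphenyl on an amine nitrogen changes activity at all stays open.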